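Swapping the Furan for an Imidazole on the Amide

A few compounds are considered here, and "the series" means these few. Any claim that something is new, unique, unknown or untested is made for them only; others in the source may bear on it.

Compound 3 `CCCC(=O)N1CCC(NS(=O)(=O)c2ccc(NC(=O)c3cc(C)oc3C(F)(F)F)c3ccccc23)CC1` shares its core with compound 1 `CCCC(=O)N1CCC(NS(=O)(=O)c2ccc(NC(=O)C3CCCCC3)c3ccccc23)CC1` and compound 2 `CCCC(=O)N1CCC(NS(=O)(=O)c2ccc(NC(=O)C(CC)CC)c3ccccc23)CC1`; the three differ only in the group attached to the carbonyl carbon of the amide. In an in vitro functional assay on CHO/Galpha16 cells for antagonist activity at C-C chemokine receptor type 8 (Homo sapiens), read by FLIPR (on this read-out higher numbers stand for weaker inhibition and lower numbers for stronger inhibition), compound 3 gives 46.9 nM. That places it second highest of the three: compound 1 gives 6.1 nM and compound 2 gives 639 nM, so the step of a 7.7-fold higher number from compound 1 to compound 3 (0.89 log units; beyond the scatter) runs against compound 3, while the step of a 14-fold lower number from compound 2 to compound 3 (1.13 log units; beyond the scatter) runs in its favour.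

Compound 4 `CCCC(=O)N1CCC(NS(=O)(=O)c2ccc(NC(=O)c3nccn3C)c3ccccc23)CC1` has not yet been measured. It differs from compound 3 in one place: 1-methyl-1H-imidazol-2-yl in place of 5-methyl-2-(trifluoromethyl)furan-3-yl on a carbonyl carbon.

Going by the values given here, the steps that bear on this change are a 7.7-fold higher number from compound 1 to compound 3 (0.89 log units; beyond the scatter) and a 14-fold lower number from compound 2 to compound 3 (1.13 log units; beyond the scatter), which show that an aromatic ring on this carbonyl carbon gave a number higher than the cyclohexyl of compound 1 but lower than the open chain of compound 2; the step of a 100-fold higher number from compound 1 to compound 2 (2.02 log units; beyond the scatter) shows how far this position can move the number. Among the compounds with values here, no measured pair shows a nitrogen-containing ring here, so the direction rests on thin ground. Compound 4 is expected to show a modest step towards a higher number, a 3.2-fold higher number from compound 3 to compound 4 (0.50 log units; beyond the scatter). Compound 4 is estimated at 150 nM, with a range from 30 nM to 800 nM.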

Compound 4, half-maximal inhibitory concentration: 20.4 nM
Compound 4: the middle estimate sits 7.4-fold (0.87 log units) above what was measured; the measured number lies below the stated range.
By their numbers in this assay, from the lowest: compound 1; then compound 4; then compound 3; then compound 2.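

In this assay, 1-methyl-1H-imidazol-2-yl in place of 5-methyl-2-(trifluoromethyl)furan-3-yl gives a 2.3-fold lower number from compound 3 to compound 4 (0.36 log units; beyond the scatter) and so shows that a ring with two nitrogen atoms is accepted on this carbonyl carbon, with the smaller group of the two giving the lower number. Compound 4 also falls in the middle of the series, as compound 3 does: the imidazole gives a 31-fold lower number from compound 2 to compound 4 (1.50 log units; beyond the scatter) against the open pentan-3-yl chain, but still a 3.3-fold higher number from compound 1 to compound 4 (0.52 log units; beyond the scatter) against the cyclohexyl, which keeps the lowest number of the four. Nothing measured on these compounds explains why the groups rank in this order.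

The furan and the imidazole differ in their ring atoms and in the groups they carry, so the step from one to the other cannot be assigned to any single feature. From the compounds shown here alone, it remains open how a plain phenyl ring, a pyridine ring, a cyclopentyl ring or the imidazole without its methyl group would compare on this carbonyl carbon.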